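Ureas on a shared core: cytotoxicity stays beyond the limit

This account rests on a few compounds, and the source may have more. Where it says the series, first, only, none or still open, it means among the compounds named here.

Compound 1 `Cc1cc(NC(=O)Nc2cccc([N+](=O)[O-])c2)c2ccccc2n1`: > 25000 nM
Compound 2 `Cc1cc(NC(=O)Nc2cccc(F)c2)c2ccccc2n1`: > 25000 nM
Compound 3 `Cc1cc(NC(=O)Nc2ccccc2F)c2ccccc2n1`: > 25000 nM

In an ADME assay on HepG2 cells (Homo sapiens) for cytotoxicity, with a stated time of 72 h (on this read-out lower numbers stand for an effect already at smaller amounts and higher numbers for an effect only at larger amounts of compound), compound 1 gives > 25000 nM, which is a limit of the assay and not a number. Compound 2 likewise gives only a limit, > 25000 nM. Compound 3 also gives a limit, > 25000 nM. Because of the limit of > 25000 nM in this assay, at which 3 of the 3 values shown sit, the step that the two limits leave unreadable from compound 2 to compound 1 cannot be sized; its change is nitro in place of fluoro on an aromatic carbon. The two cores differ as 2-fluorophenyl in place of 3-fluorophenyl on an amide-type nitrogen, and the step that the two limits leave unreadable from compound 2 to compound 3 is equally unreadable. Compound 4 `Cc1cc(NC(=O)Nc2ccccc2[N+](=O)[O-])c2ccccc2n1` has not been measured. It differs from compound 3 by nitro in place of fluoro on an aromatic carbon, the same kind of change as from compound 2 to compound 1, yet ortho to a large group rather than meta to a large group. For compound 4 the step that the limit leaves unreadable from compound 3 to compound 4 is expected to stay flat, resting on compound 3 sitting at > 25000 nM. Compound 4 is thus estimated at 40000 nM, most likely again only a limit.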

Compound 4, half-maximal effective concentration: > 25000 nM
Compound 4 ended at the assay's limit (the forecaster's own chance of this, stated with the estimate: 85%); the middle value lies beyond the limit too.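

Compound 3 and compound 4 give no step that can be read, because both values are limits: the limit of > 25000 nM in this assay, at which 4 of the 4 values shown sit.

On these data alone, whether compound 1, compound 2, compound 3 and compound 4 differ at all in this assay stays open.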